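From compound 3 to compound 4: working notes

The compounds below may be only part of what the source reports. "The series", "measured", "known", "first", "only" and "open" are said of these compounds alone.

Measured so far in an ADME assay on MRC5 cells (Homo sapiens) for cytotoxicity, read by fluorescence, with a stated time of 72 h; a higher number here means a weaker inhibitor, a lower number a stronger inhibitor:
- compound 1 `O=[N+]([O-])c1cnc2n1C[C@@H](COc1ccc(-c3ccc(F)cc3)nc1)O2` gives 55000 nM as a number
- compound 2 `CC1(COc2ccc(-c3ccc(OC(F)(F)F)cc3)cn2)Cn2cc([N+](=O)[O-])nc2O1` gives > 64000 nM as a limit
- compound 3 `CC1(COc2ccc(OC(F)(F)F)cc2)Cn2ccnc2O1` gives > 64000 nM as a limit

Compound 3 has no number in this assay: its > 64000 nM is a limit of the assay. The series is dominated by the limit of > 64000 nM in this assay, at which 2 of the 3 values shown sit, and compound 1 alone gives a number, 55000 nM, in the same range of the scale.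

Compound 4 `CC1(COc2ccc(OC(F)(F)F)cc2)Cn2cc(CO)nc2O1` differs from compound 3 in one place, hydroxymethyl in place of hydrogen on an aromatic carbon of the five-membered aromatic ring. Among the compounds with values here, no measured pair shows this change, so the expectation is weakly founded. No shift beyond the scatter is expected in this assay, in either direction. The estimated step is a number no higher from compound 3 to compound 4 (the limit leaves the size open), to be read against a limit rather than a number. For compound 4 the estimated value is 64000 nM, with an expected range from 32000 nM to 100000 nM, and a report as a limit is likely.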

Compound 4, half-maximal inhibitory concentration: > 64000 nM
Compound 4 ended at the assay's limit; the forecaster's own chance of this, stated with the estimate: 70%; the middle value sits exactly at the limit.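

In this assay compound 3 and compound 4 are both reported only as limits of the assay, so no step can be read between them. The compounds shown leave open whether hydroxymethyl in place of hydrogen on an aromatic carbon changes the half-maximal inhibitory concentration at all, with most values sitting at one limit: the limit of > 64000 nM in this assay, at which 3 of the 4 values shown sit.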